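The source may hold more compounds than are shown below. What is called first, only, known or untested is meant among the compounds shown, and "the series" means these compounds.

Compound 2 `OC[C@H]1O[C@@H](n2cnc3c(CSc4ccccc4)ncnc32)[C@H](O)[C@@H]1O` sits at a limit in a functional assay on Huh-7 cells (Homo sapiens) for cytotoxicity, read by MTT assay, with a stated time of 3 days; on this read-out lower numbers stand for higher toxicity in this test and higher numbers for lower toxicity in this test: its reading of > 100000 nM is a limit of the assay, not a number. Compound 1 `[N-]=[N+]=NCc1ncnc2c1ncn2[C@@H]1O[C@H](CO)[C@@H](O)[C@H]1O` also gives only a limit, > 250000 nM. Compound 3 `CC(=O)N(Cc1ncnc2c1ncn2[C@@H]1O[C@H](CO)[C@@H](O)[C@H]1O)C1CCCCC1` likewise gives only a limit, > 100000 nM. Going by the values given here, the single measured step, a step that the two limits leave unreadable from compound 1 to compound 2, is thus unreadable. Compound 4 `OC[C@H]1O[C@@H](n2cnc3c(COc4ccccc4)ncnc32)[C@H](O)[C@@H]1O` differs from compound 2 by phenoxy in place of phenylsulfanyl on a saturated chain carbon bound to an aromatic carbon. Among the compounds with values here, no measured step bears on this change, since every value shown sits at a limit, either the limit of > 100000 nM in this assay, at which 2 of the 3 values shown sit, or (the limit of > 250000 nM in this assay, at which 1 of the 3 values shown sits). The expected step is a step that the limit leaves unreadable from compound 2 to compound 4, with no direction beyond the scatter. Compound 4 is therefore expected to give 150000 nM, between 50000 nM and 400000 nM, most likely again reported as a limit.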

Compound 4, half-maximal cytotoxic concentration: > 100000 nM
Compound 4 ended at the assay's limit; the forecaster's own chance of this, stated with the estimate: 85%; the middle value does not contradict the limit.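

Compound 4 gives only a limit, as do compound 1 and compound 2, and the steps to compound 4 from compound 1 and compound 2 cannot be read. The compounds shown leave open whether phenoxy and phenylsulfanyl differ at all in this assay.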